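The source may hold more compounds than are shown below. What is called first, only, known or untested is meant among the compounds shown, and "the series" means these compounds.

Measured compounds:
Compound 1, `CCCS(=O)(=O)Nc1ccc(F)c(C(=O)c2n[nH]c3ncc(-c4cccc(C)c4)cc23)c1F`, gives 15% in an assay for binding affinity to dual specificity mitogen-activated protein kinase kinase 4 (Homo sapiens), read by KINOMEscan, tested at 100 nM; on this read-out higher numbers stand for a weaker effect at the one concentration tested and lower numbers for a stronger effect.
Compound 2, `CCCS(=O)(=O)Nc1ccc(F)c(C(=O)c2n[nH]c3ncc(-c4ccc(C)cc4)cc23)c1F`, gives 5.4%.
Compound 3, `CCCS(=O)(=O)Nc1ccc(F)c(C(=O)c2n[nH]c3ncc(-c4cccc(N)c4)cc23)c1F`, gives 1.6%.

Compound 1 has the highest number of the three. Its step to compound 2, a number 9.6 percentage points lower from compound 1 to compound 2 (within the scatter), lies within the scatter, while its step to compound 3, a number 13.4 percentage points lower from compound 1 to compound 3 (beyond the scatter), goes beyond it and counts as modest. Compound 4, `CCCS(=O)(=O)Nc1ccc(F)c(C(=O)c2n[nH]c3ncc(-c4cccc(N(C)C)c4)cc23)c1F`, differs from compound 1 by dimethylamino in place of methyl on an aromatic carbon. Within the data shown here, the step that bears on this is the one to compound 3, where a nitrogen-bearing group also replaced methyl at the same place and the number fell modestly. A drop of similar or smaller size is therefore expected, a number 8 percentage points lower from compound 1 to compound 4 (within the scatter). Compound 4 is estimated at 7%, within the range 1% to 22%.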

Compound 4, a percentage reported as activity, at one concentration (the size of the read-out at that concentration, not a potency): 26%
Compound 4: the middle estimate sits 19 percentage points below what was measured, outside the stated range (above it).
By their numbers in this assay, from the lowest: compounds 3, 2 and 1 (each within the scatter of the next, the first and the last beyond it); then compound 4.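

Putting nitrogen at this place does not by itself lower the number: dimethylamino in place of methyl gives a number 11 percentage points higher from compound 1 to compound 4 (beyond the scatter) and so goes the opposite way from amino. The two methyl groups on that nitrogen make a clear difference, with a number 24.4 percentage points higher from compound 3 to compound 4 (beyond the scatter), and the 3-(dimethylamino)phenyl group also compares poorly with 4-methylphenyl, with a number 20.6 percentage points higher from compound 2 to compound 4 (beyond the scatter). Nothing available here explains this rise.

Still open, from the compounds shown here alone, is whether methylamino, with one methyl on the nitrogen, would behave more like amino or like dimethylamino. An acetamide at this place would ask the same question of a different nitrogen group.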